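Swapping the nitrophenyl arm of a chalcone for methoxyphenyl

This account rests on a few compounds, and the source may have more. Where it says the series, first, only, none or still open, it means among the compounds named here.

Among the compounds with values here, compound 2 `COc1ccc(C(=O)/C=C/c2ccc([N+](=O)[O-])cc2)c2c1C=CC(C)(C)O2` is the only compound here with a true number in a functional assay on HepG2 cells (Homo sapiens) for antiproliferative activity, read by MTT assay, with a stated time of 24 h (a higher number here means a weaker inhibitor, a lower number a stronger inhibitor), where compound 2 gives 2610 nM. Compound 1 `COc1ccc(C(=O)/C=C/c2ccc(-c3ccccc3)cc2)c2c1C=CC(C)(C)O2` gives only a limit of this assay, > 10000 nM. Compound 3 `COc1ccc(C(=O)/C=C/c2ccc(C(F)(F)F)cc2)c2c1C=CC(C)(C)O2` likewise gives only a limit, > 10000 nM. Compound 4 `COc1ccccc1/C=C/C(=O)c1ccc(OC)c2c1OC(C)(C)C=C2` differs from compound 2 by 2-methoxyphenyl in place of 4-nitrophenyl on a double-bonded chain carbon bound to a double-bonded chain carbon. Within the data shown here, two measured steps bear on this change: an at least 3.8-fold lower number from compound 1 to compound 2 (0.58 log units; beyond the scatter), and an at least 3.8-fold higher number from compound 2 to compound 3 (0.58 log units; beyond the scatter), so each replacement of nitro so far has pushed the value toward (the limit of > 10000 nM in this assay, at which 2 of the 3 values shown sit). A higher number is therefore expected, a 3.1-fold higher number from compound 2 to compound 4 (0.49 log units; beyond the scatter). The expected value for compound 4 is 8000 nM, within a range from 3000 nM to 20000 nM, with a fair chance that only a limit is reported.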

Compound 4, half-maximal inhibitory concentration: > 10000 nM
Compound 4 was reported as a limit; the forecaster's own chance of this, stated with the estimate: 55%; middle value at least 1.2-fold (0.09 log units) away from the limit.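

Replacing the whole 4-nitrophenyl arm, not just the nitro group on an aromatic carbon, gives an at least 3.8-fold higher number from compound 2 to compound 4 (0.58 log units; beyond the scatter) in this assay. As far as these compounds go, the value for compound 4 is only a limit, so the true size of this step stays unknown. Compound 2 remains the only compound with a true number, and a third kind of replacement has now failed to match it: the limit of > 10000 nM in this assay, at which 3 of the 4 values shown sit.

Compounds 1, 3 and 4 all end at limits, so they cannot be ranked against one another. From the compounds shown here alone, whether an amine or a nitrile on this aromatic ring would give a true number remains open.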